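Replacing the Furan Ring in an Enone Series

The source may report more compounds than this note shows. Statements on the series, on what has been measured and on what is new or still open speak of the compounds shown alone.

Three compounds sharing one core were measured in a functional assay on MCF7 cells (Homo sapiens) for antiproliferative activity, read by XTT assay, with a stated time of 72 h; on this read-out higher numbers stand for weaker inhibition and lower numbers for stronger inhibition:

Compound 1 `COc1ccc(-c2cc3ccccc3nc2/C=C/C(=O)c2ccccc2)cc1` gives 4040 nM.
Compound 2 `COc1ccc(-c2cc3ccccc3nc2/C=C/C(=O)c2ccc(O)cc2)cc1` gives 6710 nM.
Compound 3 `COc1ccc(-c2cc3ccccc3nc2/C=C/C(=O)c2ccco2)cc1` gives 710 nM.

Compound 3 has the lowest number of the three in this assay, and both of its gaps to the others lie beyond the scatter: a 5.7-fold lower number from compound 1 to compound 3 (0.76 log units; beyond the scatter) and a 9.5-fold lower number from compound 2 to compound 3 (0.98 log units; beyond the scatter). The step of a 1.7-fold higher number from compound 1 to compound 2 (0.22 log units; within the scatter) stays within the scatter.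

Compound 4 `COc1ccc(-c2cc3ccccc3nc2/C=C/C(=O)c2ccsc2)cc1` is not yet measured. The change is thiophen-3-yl in place of furan-2-yl on a carbonyl carbon. For the measured compounds named here, no measured step shows this exact swap. What is known is that the five-membered furan-2-yl in compound 3 gave a lower number than phenyl or 4-hydroxyphenyl in the same place, as the steps of a 5.7-fold lower number from compound 1 to compound 3 (0.76 log units; beyond the scatter) and a 9.5-fold lower number from compound 2 to compound 3 (0.98 log units; beyond the scatter) show. Compound 4 keeps a five-membered ring with one hetero atom, so a value near that of compound 3 is expected, with a modest rise allowed. The step expected for compound 4 is a 1.7-fold higher number from compound 3 to compound 4 (0.23 log units; within the scatter). For compound 4 the estimate in this assay is 1200 nM, within 400 nM to 4000 nM.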

Compound 4, half-maximal inhibitory concentration: 6010 nM
For compound 4 the middle estimate is 5.0-fold (0.70 log units) below the measured one; measured number above the stated range.
By their numbers in this assay, from the lowest: compound 3; then compounds 1, 4 and 2 (each within the scatter of the next).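

The swap of furan-2-yl for thiophen-3-yl, two rings with the same heavy-atom count and one hetero atom each, gives an 8.5-fold higher number from compound 3 to compound 4 (0.93 log units; beyond the scatter) in this assay, so on this carbonyl carbon a five-membered aromatic ring with one hetero atom does not by itself keep the low number of compound 3. Thiophen-3-yl instead falls level with phenyl and 4-hydroxyphenyl, since a 1.5-fold higher number from compound 1 to compound 4 (0.17 log units; within the scatter) and a 1.1-fold lower number from compound 2 to compound 4 (0.05 log units; within the scatter) both leave furan-2-yl as the only group shown that stands apart. The data shown offer no measurement that accounts for this gap between the two rings.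

The swap changes both the hetero atom and the ring carbon that carries the carbonyl, and the compounds shown cannot separate these two changes. Thiophen-2-yl or furan-3-yl in the same place would pull them apart.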